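A Chloro-to-Iodo Swap at the Assay Limit

The source may report more compounds than this note shows. Statements on the series, on what has been measured and on what is new or still open speak of the compounds shown alone.

Three related compounds have been tested so far, and none of them gives a number that can be compared. In a functional assay on Vero cells (Chlorocebus sabaeus) for inhibition (a lower number here means a stronger inhibitor, a higher number a weaker inhibitor), compound 1 `O=c1[nH]c(=O)n([C@@H]2CS[C@@H](CO)O2)cc1Cl` gives > 100000 nM, which is a limit of the assay and not a number.

Compound 2 `CNc1ncnc2c1ncn2[C@H]1CS[C@@H](CO)O1` gives > 100000 nM, again a limit. Compound 3 `Cc1cn([C@@H]2CS[C@@H](CO)O2)c(=O)nc1N` gives > 100000 nM, also a limit. Compound 1 therefore has no rank among the three, as compound 1, compound 2 and compound 3 all share (the limit of > 100000 nM in this assay, at which 3 of the 3 values shown sit).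

The next compound to be tested is compound 4 `O=c1[nH]c(=O)n([C@@H]2CS[C@@H](CO)O2)cc1I`. It keeps the core of compound 1 and carries iodo in place of chloro on an aromatic carbon of a six-membered aromatic ring with 2 nitrogen: iodo in place of chloro on an aromatic carbon.

Going by the values given here, no measured step between two compounds is available to show how large such an exchange might be. A single change of this kind is therefore expected to shift this assay by nothing beyond the usual scatter. The estimated step is a number no higher from compound 1 to compound 4 (the limit leaves the size open).

Compound 4 is expected at about 100000 nM, with an estimated range from 30000 nM to 300000 nM.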

Compound 4, half-maximal inhibitory concentration: > 100000 nM
Compound 4: a limit, no number; the forecaster's own chance of this, stated with the estimate: 85%; the middle value lies on the limit itself.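

Compound 4 gives > 100000 nM in this assay, which is a limit of the assay and not a number. Compound 1 also stands at a limit, so no step can be read between compound 1 and compound 4: the limit of > 100000 nM in this assay, at which 4 of the 4 values shown sit.

The compounds shown leave open whether iodo and chloro differ at all in this inhibition, since none of the four gives a number.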